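The source may report more compounds than this note shows. Statements on the series, on what has been measured and on what is new or still open speak of the compounds shown alone.

The series shares one core, seen in compound 1 `Clc1ccc(/C=N/c2sc3c(c2-c2nc4ccccc4s2)CCCC3)c(Cl)c1`, compound 2 `C(=N/c1sc2c(c1-c1nc3ccccc3s1)CCCC2)\c1ccccc1` and compound 3 `O=[N+]([O-])c1ccccc1/C=N/c1sc2c(c1-c1nc3ccccc3s1)CCCC2`, and differs only in the group on the carbon with a double bond to nitrogen. In an ADME assay on HepG2 cells (Homo sapiens) for cytotoxicity, read by MTT assay, with a stated time of 72 h (on this read-out higher numbers stand for lower toxicity in this test and lower numbers for higher toxicity in this test), compound 1 gives 384 ug/mL, compound 2 gives 308 ug/mL and compound 3 gives 393 ug/mL. Compound 3 has the highest of the three numbers, but its steps to the others, a 1.0-fold higher number from compound 1 to compound 3 (0.01 log units; within the scatter) and a 1.3-fold higher number from compound 2 to compound 3 (0.11 log units; within the scatter), are within the scatter, as is a 1.2-fold lower number from compound 1 to compound 2 (0.10 log units; within the scatter), so the three numbers cannot be told apart on this read-out.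

Compound 4 `Oc1ccccc1/C=N/c1sc2c(c1-c1nc3ccccc3s1)CCCC2` has not yet been measured in this assay. The change from compound 3 is hydroxy in place of nitro on an aromatic carbon. Going by the values given here, the one measured step of the same kind, a group placed on the ring, a 1.3-fold higher number from compound 2 to compound 3 (0.11 log units; within the scatter), stays within the scatter, and replacing the whole ring group, a 1.2-fold lower number from compound 1 to compound 2 (0.10 log units; within the scatter) and a 1.0-fold higher number from compound 1 to compound 3 (0.01 log units; within the scatter), also did. Nothing measured here moves the read-out beyond the scatter, so no step beyond the scatter is expected for compound 4 in this assay: the estimated step is a 1.1-fold lower number from compound 3 to compound 4 (0.04 log units; within the scatter). Compound 4 is therefore expected to give about 360 ug/mL, with a range from 200 ug/mL to 620 ug/mL.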

Compound 4, half-maximal cytotoxic concentration: 114 ug/mL
Compound 4: middle estimate off by 3.2-fold (0.50 log units), on the high side; measured number below the stated range.
By their numbers in this assay, from the lowest: compound 4; then compounds 2, 1 and 3 (each within the scatter of the next).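

Hydroxy on an aromatic carbon ortho to a large group moves the read-out beyond the scatter in this assay, with a 3.4-fold lower number from compound 3 to compound 4 (0.54 log units; beyond the scatter) and, against the unsubstituted phenyl, a 2.7-fold lower number from compound 2 to compound 4 (0.43 log units; beyond the scatter), whereas nitro on the same ring stayed within the scatter of hydrogen. The shift also holds against the 2,4-dichlorophenyl group, with a 3.4-fold lower number from compound 1 to compound 4 (0.53 log units; beyond the scatter), so this position is not indifferent to its substituent: among the four compounds, compound 4 alone stands apart, and its lower number means higher toxicity in this test. No measured data shown here bear on the origin of this shift.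

The compounds shown leave open whether the lower number is specific to hydroxy or extends to other groups at this place, such as an amine or a carboxylic acid. Methoxy at the same place would show whether the shift persists when the hydroxy hydrogen is replaced by a methyl group, and a second hydroxy compound on a different core would show whether the step carries beyond this series.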